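Trimming one ring nitrogen from the strongest amide

A few compounds are considered here, and "the series" means these few. Any claim that something is new, unique, unknown or untested is made for them only; others in the source may bear on it.

Three amides sharing a core were compared in an assay for inhibition of Nicotinamide phosphoribosyltransferase (Homo sapiens), read by mass spectrometry, with stated times of 15 min and 30 min; a lower number here means a stronger inhibitor, a higher number a weaker inhibitor. Compound 1 `O=C(NCc1ccc(S(=O)(=O)c2ccccc2)cc1)c1ccc2nncn2c1` gives 370 nM. Compound 2 `O=C(NCc1ccc(S(=O)(=O)c2ccccc2)cc1)c1cn2ccnc2cn1` gives 150 nM, and a 2.5-fold lower number from compound 1 to compound 2 (0.39 log units; beyond the scatter). Compound 3 `O=C(NCc1ccc(S(=O)(=O)c2ccccc2)cc1)c1cnc2nccn2c1` gives 2 nM, the lowest of the three numbers: a 190-fold lower number from compound 1 to compound 3 (2.27 log units; beyond the scatter), and a 75-fold lower number from compound 2 to compound 3 (1.88 log units; beyond the scatter). Compound 4 `O=C(NCc1ccc(S(=O)(=O)c2ccccc2)cc1)c1ccc2nccn2c1` has not yet been measured. It differs from compound 3 in that (a group of 9 heavy atoms (7 carbon, 2 nitrogen; one five-membered aromatic ring with 2 hetero atoms, one six-membered aromatic ring with 1 hetero atom) in place of a group of 9 heavy atoms (6 carbon, 3 nitrogen; one five-membered aromatic ring with 2 hetero atoms, one six-membered aromatic ring with 2 hetero atoms), on a carbonyl carbon). For the measured compounds named here, the steps that bear on this are the exchanges of the same bicyclic group on the carbonyl carbon, which were large in both cases leading to compound 3 and modest between compound 1 and compound 2. The group entering compound 4 keeps the five-membered aromatic ring with 2 hetero atoms but carries a six-membered aromatic ring with 1 hetero atom in place of one with 2, so a step in this assay beyond the scatter toward a higher number is expected, though the evidence does not fix its size. Compound 4 is therefore estimated at 40 nM, within 8 nM to 250 nM, which is expected to be a 20-fold higher number from compound 3 to compound 4 (1.30 log units; beyond the scatter).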

Compound 4, half-maximal inhibitory concentration: 18 nM
For compound 4 the middle estimate is 2.2-fold (0.35 log units) above the measured one, within the range that was stated.
By their numbers in this assay, from the lowest: compound 3; then compound 4; then compound 2; then compound 1.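

In this assay the group with a six-membered aromatic ring with 1 hetero atom costs potency against compound 3, a 9.0-fold higher number from compound 3 to compound 4 (0.95 log units; beyond the scatter), yet this step is only modest. The count of hetero atoms in the six-membered ring does not alone set the order at this carbonyl carbon: an 8.3-fold lower number from compound 2 to compound 4 (0.92 log units; beyond the scatter), so the group with 1 hetero atom in that ring outperforms a group with 2, while compound 1 also has 1 there and still shows the step of a 21-fold lower number from compound 1 to compound 4 (1.31 log units; beyond the scatter). No measurement shown accounts for these differences.

The compounds shown leave open how a methyl group or an amine on the bicyclic group of compound 3 or compound 4 would alter these numbers. They also leave open whether a fluorine atom there would do so.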